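The source may hold more compounds than are shown below. What is called first, only, known or untested is meant among the compounds shown, and "the series" means these compounds.

Measured so far in an ADME assay on MT2 cells (Homo sapiens) for cytotoxicity, read by MTT assay; on this read-out lower numbers stand for higher toxicity in this test and higher numbers for lower toxicity in this test:
- compound 1 `CSCc1ccc(Nc2ncc(Cc3c(F)cccc3F)o2)cc1`: > 100000 nM
- compound 2 `Fc1cccc(F)c1Cc1cnc(Nc2ccc(-c3cccnc3)c(Cl)c2)o1`: 8900 nM
- compound 3 `Clc1cccc(Cl)c1Cc1nnc(Nc2ccc(COCc3ccccn3)cc2)o1`: > 100000 nM

Compound 1 stands at a limit of this assay: its value > 100000 nM is a bound, not a number. Compound 3 also stands at a limit, > 100000 nM. Going by the values given here, compound 2 is the only member with a numeric reading, 8900 nM. Among the compounds with values here, two of the three values therefore sit at the limit of > 100000 nM in this assay, at which 2 of the 3 values shown sit, and no pair of measured compounds differs in a single place, so no measured step is available to size the effect of any change.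

Compound 4 `Fc1cccc(F)c1Cc1cnc(Nc2ccc(Oc3cccnc3)cc2)o1` is the next to be measured in this assay. Relative to compound 1 the change is (pyridin-3-yl)oxy in place of (methylsulfanyl)methyl on an aromatic carbon. Within the data shown here, with no measured step, the size of the change from compound 1 to compound 4 is uncertain; the expectation is a step toward lower numbers of modest size, possibly none beyond the scatter, since compound 1 itself is only a bound. Compound 2 shows that a member of this series can read below the limit, so a numeric value for compound 4 is plausible. Compound 4 is estimated at 60000 nM, in the range 15000 nM to 150000 nM, meaning an expected step of an at least 1.6-fold lower number from compound 1 to compound 4 (0.22 log units; that floor lies within the scatter).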

Compound 4, half-maximal cytotoxic concentration: 22000 nM
Compound 4: the middle estimate sits 2.7-fold (0.44 log units) above what was measured; the measured number falls inside the stated range.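

Going by these compounds alone, at the aromatic carbon para to a large group, (pyridin-3-yl)oxy in place of (methylsulfanyl)methyl gives the first step that can be read in this assay, an at least 4.5-fold lower number from compound 1 to compound 4 (0.65 log units; beyond the scatter), so the group at this position alone is enough to bring a member of the series off the limit of the assay. Compound 1 reads > 100000 nM, which is a limit and not a number. As far as these compounds go, the step therefore has a floor but no upper end, and its true size stays unknown because its starting point is a bound: the limit of > 100000 nM in this assay, at which 2 of the 4 values shown sit.

The compounds shown do not separate the contribution of the pyridine ring from that of the oxygen linking it, and a plain methoxy, a phenoxy or an amine on the same aromatic carbon would be needed to tell these apart. From the compounds shown here alone, it also remains open whether the same change has a similar effect with the other groups on the shared core, since steps involving compound 2 and compound 3 cannot be read.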